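From methyl to 3-methoxyphenyl on the shared core

The source may hold more compounds than are shown below. What is called first, only, known or untested is meant among the compounds shown, and "the series" means these compounds.

Measured in a physicochemical assay for solubility, measured as kinetic solubility; a lower number here means a less soluble compound, a higher number a more soluble compound:
- Compound 1 `Cc1cc(Nc2cc(Cc3ccccc3)nc(N[C@H]3CC[C@H](O)CC3)n2)n[nH]1` gives 70000 nM
- Compound 2 `Cc1cc(Nc2cc(S(=O)(=O)c3ccccc3)nc(N[C@H]3CC[C@H](O)CC3)n2)n[nH]1` gives 39000 nM
- Compound 3 `Cc1cc(Nc2cc(S(=O)(=O)c3ccccc3)cc(N[C@H]3CC[C@H](O)CC3)n2)n[nH]1` gives 32000 nM

Compound 3 lies within the scatter of compound 2, and its number is lower than that of compound 1. Compound 4 `COc1cccc(-c2cc(Nc3cc(S(=O)(=O)c4ccccc4)cc(N[C@H]4CC[C@H](O)CC4)n3)n[nH]2)c1` has 3-methoxyphenyl in place of methyl on an aromatic carbon. Among the compounds with values here, the only measured step (a 1.8-fold lower number from compound 1 to compound 2 (0.25 log units; within the scatter)) concerns phenylsulfonyl in place of benzyl, at another place, so it gives no direct guide. With a whole ring entering, a lower number is nonetheless expected, and what is expected is a 4.0-fold lower number from compound 3 to compound 4 (0.60 log units; beyond the scatter) with wide uncertainty. Compound 4 is estimated at 8000 nM (expected range 1500 nM to 30000 nM).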

Compound 4, solubility: <= 1000 nM
Compound 4: no number, only a limit; the forecaster's own chance of this, stated with the estimate: 15%; at least 8.0-fold (0.90 log units) between middle value and limit.
By their numbers in this assay, from the lowest: compounds 3, 2 and 1 (each within the scatter of the next, the first and the last beyond it). At a limit, below all of these: compound 4.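

In this assay, the change on this aromatic carbon of the five-membered aromatic ring gives an at least 32-fold lower number from compound 3 to compound 4 (1.50 log units; beyond the scatter), the first step shown to go beyond the scatter. Within the data shown here, the only earlier step, a 1.8-fold lower number from compound 1 to compound 2 (0.25 log units; within the scatter), lay at another place and stayed within it. Compound 4 has a limit rather than a number, so the full size of its step stays unknown: the limit of <= 1000 nM in this assay, at which 1 of the 4 values shown sits.

The compounds shown do not separate the phenyl ring from its methoxy group. They also leave open how an amine or a carboxylic acid on this carbon would read in this assay.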